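Chloro Added Ortho to the Sulfamoyloxy Group of Compound 1

This account rests on a few compounds, and the source may have more. Where it says the series, first, only, none or still open, it means among the compounds named here.

Three compounds share a core, differing only in where the sulfamoyloxy group sits on the outer ring: compound 1 `Cc1ccccc1N(C)C(=O)c1ccc(-c2ccc(OS(N)(=O)=O)cc2)o1`, compound 2 `Cc1ccccc1N(C)C(=O)c1ccc(-c2cccc(OS(N)(=O)=O)c2)o1` and compound 3 `Cc1ccccc1N(C)C(=O)c1ccc(-c2ccccc2OS(N)(=O)=O)o1`. In an assay on T47D cells for inhibition of Steryl-sulfatase (Homo sapiens), read by HPLC, with a stated time of 24 h (a lower number here means a stronger inhibitor, a higher number a weaker inhibitor), compound 1 gives 31 nM. Among the measured compounds shown here, for compound 2 the result in this assay is "nd" (no result reported), and for compound 3 it is likewise "nd" (no result reported), so compound 1 holds the only number in this small set and there is nothing to rank it against.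

Compound 4 `Cc1ccccc1N(C)C(=O)c1ccc(-c2ccc(OS(N)(=O)=O)c(Cl)c2)o1` is built from compound 1 by one change, (chloro in place of hydrogen on an aromatic carbon), the new group sitting ortho to the sulfamoyloxy group and meta to a large group. For the measured compounds named here, no pair of measured compounds shows what such a change does here, so no step size can be read from the data. The expected step from compound 1 to compound 4 in this assay is a 2.1-fold lower number from compound 1 to compound 4 (0.32 log units; beyond the scatter), a modest move toward a stronger inhibitor rather than a change beyond the scatter. Compound 4 is thus estimated at 15 nM in this assay, within a range from 4 nM to 80 nM.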

Compound 4, half-maximal inhibitory concentration: 27 nM
Estimate against measurement, compound 4: 1.8-fold (0.26 log units) below; low and high end bracket the measured number.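

Among the compounds shown here, compound 1 held the only number in the earlier set, so nothing could be said about how a change on its outer ring would play out. In this assay, chloro in place of hydrogen on an aromatic carbon, ortho to a sulfamoyloxy group, gives a 1.1-fold lower number from compound 1 to compound 4 (0.06 log units; within the scatter) and the two compounds cannot be told apart, so this carbon can carry a chlorine atom while the inhibitor keeps its strength in the nanomolar range. No measurement at hand explains why this swap leaves the number where it is.

Going by these compounds, what a fluoro group, a methoxy group or an amine would do on this same carbon remains open. So does the effect of chloro on the other carbons of that ring, and whether the same holds when the sulfamoyloxy group sits elsewhere.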